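Swapping Acetyl for Chloro on a Shared Core

This account rests on a few compounds, and the source may have more. Where it says the series, first, only, none or still open, it means among the compounds named here.

Of the compounds shown here, three built on one shared core have been measured in a functional assay on SK-MEL-5 cells (Homo sapiens) for inhibition, read by sulforhodamine B assay, with a stated time of 48 h, tested at 10 uM; a higher number here means more inhibition at the concentration tested (going by the name of the read-out), a lower number less inhibition. Compound 1 `Brc1cn2ccnc2c(-c2ccc3ncn(C4CCCCC4)c3c2)n1` gives 13.4%. Compound 2 `COc1ccc(-c2cn3ccnc3c(-c3ccc4ncn(C5CCCCC5)c4c3)n2)cc1` gives 92.3%, and compound 3 `CC(=O)c1ccc(-c2cn3ccnc3c(-c3ccc4ncn(C5CCCCC5)c4c3)n2)cc1` gives 24.8%. On these numbers compound 3 stands second highest of the three: it sits beyond the scatter above compound 1, as the step of a number 11.4 percentage points higher from compound 1 to compound 3 (beyond the scatter) shows, and far beneath compound 2, as the step of a number 67.5 percentage points lower from compound 2 to compound 3 (beyond the scatter) shows.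

Compound 4 `Clc1ccc(-c2cn3ccnc3c(-c3ccc4ncn(C5CCCCC5)c4c3)n2)cc1` differs from compound 3 by the change (chloro in place of acetyl on an aromatic carbon). Going by the values given here, no measured step puts a chloro group on this ring, so only the neighbouring steps can guide the expectation. The step of a number 78.9 percentage points higher from compound 1 to compound 2 (beyond the scatter) shows that a 4-methoxyphenyl group lifts the read-out greatly, while the step of a number 11.4 percentage points higher from compound 1 to compound 3 (beyond the scatter) shows that a 4-acetylphenyl group lifts it only modestly. As far as these compounds go, a chloro group is neither of these, and its effect remains open. The expected step of a number 10.2 percentage points higher from compound 3 to compound 4 (beyond the scatter) is therefore modest compared with those measured, with the direction uncertain. Compound 4 is estimated at 35%, within a range from 10% to 75%.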

Compound 4, a percentage reported as inhibition, at one concentration (the size of the read-out at that concentration, not a potency): 12.4%
Compound 4: the middle estimate sits 22.6 percentage points above what was measured, and the stated range covers the measured number.
By their numbers in this assay, from the lowest: compounds 4 and 1 (each within the scatter of the next); then compound 3; then compound 2.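

In this assay the step from bromo to 4-chlorophenyl is a number 1 percentage points lower from compound 1 to compound 4 (within the scatter) and leaves the two compounds level, so placing a benzene ring at this position is not enough on its own to raise the read-out. What that ring carries matters far more: chloro in place of acetyl gives a number 12.4 percentage points lower from compound 3 to compound 4 (beyond the scatter) on the shared core, and chloro in place of methoxy gives a number 79.9 percentage points lower from compound 2 to compound 4 (beyond the scatter) in a comparison that sets the 4-methoxyphenyl group well apart from the 4-chlorophenyl group. No measurement at hand explains why these groups on the ring give such different readings.

The compounds shown leave open whether the high reading depends on methoxy alone or would also appear with a group such as hydroxyl, ethoxy or dimethylamino in the same place on the ring. As far as these compounds go, each number is also a reading at one concentration, so how the compounds would compare in potency remains open as well.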